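The source may hold more compounds than are shown below. What is called first, only, known or untested is meant among the compounds shown, and "the series" means these compounds.

Values in a functional assay on A-375 cells (Homo sapiens) for antiproliferative activity, read by MTT assay, with a stated time of 72 h; on this read-out higher numbers stand for weaker inhibition and lower numbers for stronger inhibition:
- Compound 1 `COc1cccc(N2C(=O)COc3ccc(-c4cnc(Cl)c(NS(=O)(=O)c5ccc(F)cc5)c4)cc32)c1`: > 40000 nM, a limit
- Compound 2 `O=C1COc2ccc(-c3cnc(Cl)c(NS(=O)(=O)c4ccc(F)cc4)c3)cc2N1C1CCCCC1`: > 40000 nM, a limit
- Compound 3 `COc1ccc(N2C(=O)COc3ccc(-c4cnc(Cl)c(NS(=O)(=O)c5ccc(F)cc5)c4)cc32)cc1`: not yet measured

Compound 2 has only a limit, > 40000 nM, and no number. Both measured compounds share it: the limit of > 40000 nM in this assay, at which 2 of the 2 values shown sit. Among the measured compounds shown here, the one measured step is a step that the two limits leave unreadable from compound 1 to compound 2, so it gives no size to carry forward.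

Next, 4-methoxyphenyl replaces cyclohexyl on the amide-type nitrogen in a ring: 4-methoxyphenyl in place of cyclohexyl on an amide-type nitrogen in a ring. Compound 1, with 3-methoxyphenyl at that nitrogen, also reports only a limit, > 40000 nM.

No readable change is expected in this assay, and the expected step is a number no higher from compound 2 to compound 3 (the limit leaves the size open). Compound 3 is estimated at 40000 nM, with an expected range of 15000 nM to 80000 nM.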

Compound 3, half-maximal inhibitory concentration: 32700 nM
The estimate for compound 3 lay 1.2-fold (0.09 log units) above the measured number; the measured number falls inside the stated range.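

In this assay, among the compounds shown here, compound 3, with 4-methoxyphenyl on the amide-type nitrogen, gives the only value shown that is a number and not a limit. The change reads as an at least 1.2-fold lower number from compound 2 to compound 3 (0.08 log units; that floor lies within the scatter) and as an at least 1.2-fold lower number from compound 1 to compound 3 (0.08 log units; that floor lies within the scatter), so these floors alone show no change at this position beyond the scatter. The series remains largely at one limit: the limit of > 40000 nM in this assay, at which 2 of the 3 values shown sit.

Going by these compounds, how far compound 1 and compound 2 lie past that limit stays open, and with it the true size of both steps. On these data alone, whether an aminoalkyl or carboxylic acid group on this nitrogen would give a clearly lower number is also open.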